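Capping the Ring Amide Nitrogen of Compound 2

The source may report more compounds than this note shows. Statements on the series, on what has been measured and on what is new or still open speak of the compounds shown alone.

For the measured compounds named here, compound 2 `COc1cc(OC)c(-c2nc3cc(/C=C4\SC(=O)NC4=O)ccc3[nH]2)cc1OC` gives 15400 nM in a functional assay on HeLa cells (Homo sapiens) for inhibition, read by MTT assay, with a stated time of 48 h (on this read-out lower numbers stand for stronger inhibition and higher numbers for weaker inhibition), one of only two numbers recorded; compound 1 `COc1ccc(-c2nc3cc(/C=C4\SC(=O)NC4=O)ccc3[nH]2)cc1OC` gives 7830 nM, and the step of a 2.0-fold higher number from compound 1 to compound 2 (0.29 log units; within the scatter) lies within the scatter. Compound 3 `COc1cc(OC)c(-c2nc3cc(/C=C4\SC(=O)N(CC(=O)N5CCOCC5)C4=O)ccc3[nH]2)cc1OC` differs from compound 2 in one place: ((morpholin-4-yl)carbonyl)methyl in place of hydrogen on an amide-type nitrogen in a ring. Going by the values given here, the single measured step concerns methoxy in place of hydrogen on an aromatic carbon and says nothing about a change on the amide-type nitrogen in a ring, so no direction can be drawn from it. Compound 3 is therefore estimated at 15000 nM, with a range of 4000 nM to 60000 nM. The expected step of a 1.0-fold lower number from compound 2 to compound 3 (0.01 log units; within the scatter) is none beyond the scatter.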

Compound 3, half-maximal inhibitory concentration: 510 nM
Compound 3: the middle estimate sits 29-fold (1.47 log units) above what was measured, outside the stated range (below it).
By their numbers in this assay, from the lowest: compound 3; then compounds 1 and 2 (each within the scatter of the next).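

In this assay, the amide-type nitrogen in the five-membered non-aromatic ring proves to be a place where a change counts: ((morpholin-4-yl)carbonyl)methyl in place of hydrogen gives a 30-fold lower number from compound 2 to compound 3 (1.48 log units; beyond the scatter). The earlier step, on an aromatic carbon, stayed within the scatter, so this is the first change shown that goes beyond it. Nothing measured here says why the number falls.

Still open, as far as these compounds go, is whether the morpholin-4-yl ring is needed, or whether a plain methyl, a carboxylic acid or a longer chain on this nitrogen would serve as well. Whether the same change would act similarly on compound 1 is also unknown.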